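Compound 2 loses its methoxymethyl chain

This account rests on a few compounds, and the source may have more. Where it says the series, first, only, none or still open, it means among the compounds named here.

In an ADME assay on Vero cells (Chlorocebus sabaeus) for cytotoxicity, read by CellTiter-Glo, with a stated time of 72 h (on this read-out lower numbers stand for higher toxicity in this test and higher numbers for lower toxicity in this test), compound 1 (`CCNc1n[n+]([O-])c2ccccc2[n+]1[O-]`) gives 17 ug/mL. Compound 2 (`COCC(C)Nc1n[n+]([O-])c2ccccc2[n+]1[O-]`) gives > 50 ug/mL, and this value is a limit of the assay, not a number. Its true position is therefore known from one side only. Going by the values given here, the one measured step, an at least 2.9-fold higher number from compound 1 to compound 2 (0.46 log units; beyond the scatter), lies beyond the scatter, and its size is bounded on one side only because it ends at the limit of > 50 ug/mL in this assay, at which 1 of the 2 values shown sits.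

The next structure is compound 3 (`CCN(CC)c1n[n+]([O-])c2ccccc2[n+]1[O-]`), and the change from compound 2 is diethylamino in place of (1-(methoxymethyl)ethyl)amino on an aromatic carbon. The methoxymethyl group leaves with this change, and compound 1 also lacks that group. Among the compounds with values here, the step to compound 1, an at least 2.9-fold higher number from compound 1 to compound 2 (0.46 log units; beyond the scatter), is the only guide, so a move back towards lower numbers is expected, of about that modest size. Within the data shown here, a single step is thin support, however, and the second ethyl group of compound 3 has no measured precedent. The estimate means an at least 2.5-fold lower number from compound 2 to compound 3 (0.39 log units; beyond the scatter), an expected step beyond the scatter. For compound 3 the estimated value is 20 ug/mL, with an expected range of 7 ug/mL to 50 ug/mL.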

Compound 3, half-maximal cytotoxic concentration: 12 ug/mL
Compound 3: the middle estimate sits 1.7-fold (0.22 log units) above what was measured; measured number inside the range.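

In this assay, the change on the aromatic carbon between two ring nitrogen atoms gives an at least 4.1-fold lower number from compound 2 to compound 3 (0.61 log units; beyond the scatter), when diethylamino stands in place of (1-(methoxymethyl)ethyl)amino. Among these three compounds, the higher number therefore goes with the (1-(methoxymethyl)ethyl)amino group of compound 2 and not with the mere presence of a substituted amino group at this position, while the second ethyl group, new in this series, gives a 1.4-fold lower number from compound 1 to compound 3 (0.15 log units; within the scatter), which leaves that change within the scatter. The value of compound 2, > 50 ug/mL, is a limit of the assay and not a number, so the step to compound 3 is bounded on one side only: the limit of > 50 ug/mL in this assay, at which 1 of the 3 values shown sits.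

The compounds shown leave open whether the oxygen of the methoxymethyl chain goes with the higher number or whether the length of the chain alone would do the same, a question that a plain propyl or butyl chain on the nitrogen, or a hydroxyl group in place of the methoxy group, would address. They also leave open how far above the limit compound 2 truly stands.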